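A bromothiophene sulfonyl in place of benzyl

The source may hold more compounds than are shown below. What is called first, only, known or untested is meant among the compounds shown, and "the series" means these compounds.

Measured compounds:
compound 1 `COc1ccc(-c2cc(=O)c3c(OC)cc(OC)cc3n2S(=O)(=O)c2cc(F)c(F)c(F)c2)cc1` — > 65500 nM
compound 2 `COc1ccc(-c2cc(=O)c3c(OC)cc(OC)cc3n2S(=O)(=O)c2cc(Cl)cc(Cl)c2O)cc1` — > 37900 nM
compound 3 `COc1ccc(-c2cc(=O)c3c(OC)cc(OC)cc3n2S(=O)(=O)Cc2ccccc2)cc1` — > 34400 nM

In a functional assay on SUP-B15 cells (Homo sapiens) for antiproliferative activity, with a stated time of 72 h (on this read-out higher numbers stand for an effect only at larger amounts of compound and lower numbers for an effect already at smaller amounts), compound 1 gives > 65500 nM, which is a limit of the assay and not a number. Compound 2 likewise gives > 37900 nM in this assay, again a limit. Compound 3 gives > 34400 nM in this assay, also a limit. Compound 3 therefore stands at a limit, as do the two other compounds the limit of > 34400 nM in this assay, at which 1 of the 3 values shown sits, the limit of > 37900 nM in this assay, at which 1 of the 3 values shown sits (the limit of > 65500 nM in this assay, at which 1 of the 3 values shown sits). The changes on the sulfonyl sulfur among these three, a step that the two limits leave unreadable from compound 1 to compound 2, a step that the two limits leave unreadable from compound 1 to compound 3 and a step that the two limits leave unreadable from compound 2 to compound 3, cannot be read in size. Every value among the three is a limit.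

Compound 4 `COc1ccc(-c2cc(=O)c3c(OC)cc(OC)cc3n2S(=O)(=O)c2ccc(Br)s2)cc1` differs from compound 3 by 5-bromothiophen-2-yl in place of benzyl on a sulfonyl sulfur. The measured steps all concern the group on the sulfonyl sulfur, the same place that changes here, yet none yields a readable size. No step beyond the scatter can be expected in this assay, and a further limit is the most probable outcome. Compound 4 is estimated at 50000 nM, ranging from 15000 nM to 200000 nM. This estimate implies a step that the limit leaves unreadable from compound 3 to compound 4, expected to be unreadable.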

Compound 4, half-maximal effective concentration: > 48200 nM
Compound 4: no number, only a limit; the forecaster's own chance of this, stated with the estimate: 80%; the middle value is on the limit's open side.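

In this assay compound 4 gives > 48200 nM, which is a limit and not a number. Its steps from compound 1, compound 2 and compound 3 cannot be read in size. The compounds shown leave open whether any group on the sulfonyl sulfur gives a readable value in this assay.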